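The source may hold more compounds than are shown below. What is called first, only, known or untested is meant among the compounds shown, and "the series" means these compounds.

Of the compounds shown here, three have been measured in a functional assay on HepG2 cells (Homo sapiens) for inhibition, read by MTT assay, with a stated time of 72 h; on this read-out lower numbers stand for stronger inhibition and higher numbers for weaker inhibition. Compound 1 `Nc1ncnc2c1c(-c1cnc3[nH]ccc3c1)nn2CCCCCC(=O)NO` gives 12900 nM, and compound 2 `Nc1nc2cc(-c3nn(CCCCC(=O)NO)c4ncnc(N)c34)ccc2o1`, which carries a different group on the shared core, gives 2100 nM. For compound 3 `Nc1ncnc2c1c(-c1cnc3[nH]ccc3c1)nn2CCCC(=O)NO` the assay reports only a limit, > 50000 nM. Compound 2 thus holds the lower of the two actual numbers, with compound 1 the nearest above it.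

Compound 4 `Nc1nc2cc(-c3nn(CCCCCCC(=O)NO)c4ncnc(N)c34)ccc2o1` keeps the core of compound 2 and changes only the chain: 2-(hydroxycarbamoyl)ethyl in place of hydroxycarbamoyl on a saturated chain carbon, four bonds along the chain from an aromatic nitrogen. This places 2-(hydroxycarbamoyl)ethyl in place of hydroxycarbamoyl on a saturated chain carbon, four bonds along the chain from an aromatic nitrogen.

Going by the values given here, one measured step bears on this change: an at least 3.8-fold higher number from compound 1 to compound 3 (0.58 log units; beyond the scatter), which is beyond the scatter. It is the same exchange in reverse, three bonds along the chain from an aromatic nitrogen, so there the longer chain carries the lower number. That step is a single pair, its size is bounded by a limit, and it was measured with the other group on the core. A moderately lower number is therefore expected in this assay, and the estimated step is a 3.0-fold lower number from compound 2 to compound 4 (0.48 log units; beyond the scatter). Compound 4 is estimated at 700 nM, with an expected range of 150 nM to 3500 nM.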

Compound 4, half-maximal inhibitory concentration: 1610 nM
For compound 4 the middle estimate is 2.3-fold (0.36 log units) below the measured one; measured number inside the range.
By their numbers in this assay, from the lowest: compounds 4 and 2 (each within the scatter of the next); then compound 1. At a limit, above all of these: compound 3.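

In this assay, the exchange of hydroxycarbamoyl for 2-(hydroxycarbamoyl)ethyl on a saturated chain carbon, four bonds along the chain from an aromatic nitrogen, gives a 1.3-fold lower number from compound 2 to compound 4 (0.12 log units; within the scatter), so on the core of compound 2 this extension brings no change that the assay can separate. The earlier pair had shown the exchange only on the core of compound 1, and the new step shows that its size does not carry over from one core to the other: the same change on two cores in this assay, an at least 3.8-fold higher number (0.58 log units; beyond the scatter) from compound 1 to compound 3 and a 1.3-fold higher number (0.12 log units; within the scatter) from compound 4 to compound 2, at least 2.9-fold (0.47 log units) apart, beyond the scatter of two such steps. Going by these compounds alone, that comparison rests on one side on a limit, the one reported for compound 3, so the size of the step on the core of compound 1 remains bounded rather than fixed: the limit of > 50000 nM in this assay, at which 1 of the 4 values shown sits.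

Going by these compounds, it remains open how the number in this assay would move with a still longer chain on the core of compound 2, and whether a shorter chain on that core would bring a step like the one on the core of compound 1. The compounds shown also leave open what a carboxylic acid in place of the hydroxycarbamoyl end would give on either core.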